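Sulfonamide piperidine series: metabolic stability working notes

The source may report more compounds than this note shows. Statements on the series, on what has been measured and on what is new or still open speak of the compounds shown alone.

Measured so far:
compound 1, `CC1CCN(C2CCN(S(=O)(=O)c3ccc(Cl)c(Cl)c3)CC2)CC1`, in an ADME assay on S9 fraction from liver (Mus musculus, strain ICR/CD-1) for metabolic stability, read by LC-MS, using NADPH, with a stated time of 5 min, tested at 2 uM; on this read-out lower numbers stand for a shorter-lived compound and higher numbers for a longer-lived compound: 0.55 h
compound 2, `CC1CCN(C2CCN(S(=O)(=O)c3ccc(Cl)cc3Cl)CC2)CC1`, in this assay: 0.25 h

Compound 2 holds the lowest of the two numbers in this assay; its nearest neighbour is compound 1, separated by a 2.2-fold lower number from compound 1 to compound 2 (0.34 log units; beyond the scatter), which is modest but beyond the scatter.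

The next compound, compound 3, `CC1CCN(C2CCN(S(=O)(=O)c3ccccc3Br)CC2)CC1`, is not yet measured. It differs from compound 2 in one place, (2-bromophenyl in place of 2,4-dichlorophenyl on a sulfonyl sulfur).

Among the measured compounds shown here, only one measured step exists, and it bears on this change indirectly: a 2.2-fold lower number from compound 1 to compound 2 (0.34 log units; beyond the scatter) shows that rearranging the two chlorines on the same phenyl ring moved the half-life in this assay by a modest amount. For the measured compounds named here, the swap to 2-bromophenyl removes one halogen and changes the other, which no measured pair covers. Going by the values given here, with no direct precedent, the expected step in this assay from compound 2 to compound 3 is small and uncertain in direction; a 1.2-fold higher number from compound 2 to compound 3 (0.08 log units; within the scatter) is the estimated step. Compound 3 is therefore expected to give about 0.3 h in this assay, within a range of 0.12 h to 0.7 h.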

Compound 3, half-life: 0.1 h
Estimate against measurement, compound 3: 3.0-fold (0.48 log units) above, and the stated range ends above it.
By their numbers in this assay, from the lowest: compound 3; then compound 2; then compound 1.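

In this assay the order of the three compounds now extends downwards: with a 2.5-fold lower number from compound 2 to compound 3 (0.40 log units; beyond the scatter), the 2-bromophenyl group gives a shorter half-life than the 2,4-dichlorophenyl group, a difference that the rearrangement of the two chlorines alone could not show. Against the other dichlorophenyl group, a 5.5-fold lower number from compound 1 to compound 3 (0.74 log units; beyond the scatter), the widest span in the series so far, which shows that changing only the group on the sulfonyl sulfur, with the core of compound 1 held constant, can move the half-life across this whole range. Nothing accompanying these half-lives bears on why the groups differ, and the cause of the steps stays unassigned.

This change alters the kind of halogen and the number of halogens on the ring together, so the compounds shown cannot separate the two contributions. Also open, going by these compounds, is where a plain phenyl, a 2-chlorophenyl, or a ring carrying a methoxy or nitrile group on the sulfonyl sulfur would fall in this order, and whether the same order of aryl groups would hold on a core with another group in place of the methyl.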